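A few compounds are considered here, and "the series" means these few. Any claim that something is new, unique, unknown or untested is made for them only; others in the source may bear on it.

Measured so far in a physicochemical assay for solubility, read by HPLC, measured as thermodynamic solubility, with a stated time of 24 h, at pH 4; a lower number here means a less soluble compound, a higher number a more soluble compound:
- compound 1 `CCCc1ccc(NC(=O)COc2cc(C)nc3ccc(OC)cc23)cc1`: 90000 nM
- compound 2 `COc1ccc2nc(C)cc(OCC(=O)Nc3ccc(C)c(C)c3)c2c1`: 410000 nM
- compound 3 `COc1ccc2nc(C)cc(OCC(=O)Nc3ccc4c(c3)CCCC4)c2c1`: 30000 nM

Not yet measured: compound 4 `COc1ccc2nc(C)cc(OCC(=O)Nc3ccc4c(c3)CCC4)c2c1`.

Compound 1 holds the middle place of the three numbers, with compound 2 reading higher and compound 3 reading lower, both gaps beyond the scatter. The change under review is 2,3-dihydro-1H-inden-5-yl in place of 4-propylphenyl on an amide-type nitrogen. It replaces 4-propylphenyl on an amide-type nitrogen, and the entering group adds a five-membered non-aromatic ring of carbon only. Going by the values given here, the one measured step at this place is a 4.6-fold higher number from compound 1 to compound 2 (0.66 log units; beyond the scatter), a modest step upward. The measured compound closest in structure to compound 4 is compound 3, which gives 30000 nM, a value that lies on the other side of compound 1. With evidence pointing both ways, no firm direction can be drawn, and no step beyond the scatter is expected. The estimated change is a 1.1-fold lower number from compound 1 to compound 4 (0.05 log units; within the scatter). For compound 4 the expected value is 80000 nM, with an estimated range from 25000 nM to 300000 nM.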

Compound 4, solubility: 120000 nM
Compound 4: the middle estimate sits 1.5-fold (0.18 log units) below what was measured; the range from low to high includes it.
By their numbers in this assay, from the lowest: compound 3; then compounds 1 and 4 (each within the scatter of the next); then compound 2.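

In this assay, 2,3-dihydro-1H-inden-5-yl in place of 4-propylphenyl on the amide-type nitrogen gives a 1.3-fold higher number from compound 1 to compound 4 (0.12 log units; within the scatter), so a five-membered non-aromatic ring of carbon only can enter at this place with no step beyond the scatter. The same group in place of 3,4-dimethylphenyl gives a 3.4-fold lower number from compound 2 to compound 4 (0.53 log units; beyond the scatter), while compound 3 gives 30000 nM and compound 4 gives 120000 nM, so the number at this place separates these groups even though all of them are carbon only. No measurement at hand bears on the reason for these differences.

As far as these compounds go, whether an amine, a carboxylic acid or a longer chain such as butyl at this place would move the number remains open. From the compounds shown here alone, all the changes shown sit on the amide-type nitrogen, so changes on the shared core also remain open.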